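Removing one pent-4-en-1-yl chain from a protected beta-lactam

The compounds below may be only part of what the source reports. "The series", "measured", "known", "first", "only" and "open" are said of these compounds alone.

Of the compounds shown here, two have been measured in an assay for inhibition of Fatty-acid amide hydrolase 1 (Homo sapiens), tested at 1 mM; a lower number here means less inhibition, a higher number more inhibition at the concentration tested (going by the name of the read-out). Compound 1 `C=CCCCC1(CCCC=C)CN([Si](C)(C)C(C)(C)C)C1=O` carries two pent-4-en-1-yl chains on one ring carbon and a bulky silyl group on the ring nitrogen; in this assay compound 1 gives 25.2%. Compound 2 `C=CCCCC1CNC1=O` has a single pent-4-en-1-yl chain and a free ring nitrogen; in this assay compound 2 gives 80.9%. Compound 1 therefore stands lowest of the two, and the gap to compound 2 is well beyond the usual scatter of such measurements.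

Compound 3 `C=CCCCC1CN([Si](C)(C)C(C)(C)C)C1=O` has not yet been measured. It differs from compound 1 in one place: hydrogen in place of pent-4-en-1-yl on a saturated ring carbon. Compound 3 thus keeps the silyl group of compound 1 but carries only one chain, like compound 2. Going by the values given here, no pair of measured compounds shows this exact change, so the size of its effect is unknown. The expectation is a rise in this assay, an estimated step of a number 22.8 percentage points higher from compound 1 to compound 3 (beyond the scatter), because compound 2 with a single chain reaches 80.9%. Compound 3 is therefore expected to give roughly 48%, with a plausible range from 22% to 75%.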

Compound 3, a percentage reported as inhibition, at one concentration (the size of the read-out at that concentration, not a potency): 76.9%
Estimate against measurement, compound 3: 28.9 percentage points below; the whole stated range lies below it.
By their numbers in this assay, from the lowest: compound 1; then compounds 3 and 2 (each within the scatter of the next).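

Replacing one pent-4-en-1-yl chain with hydrogen on the saturated ring carbon gives, in this assay, a number 51.7 percentage points higher from compound 1 to compound 3 (beyond the scatter), so this single change separates the low reading of compound 1 from the high readings. The earlier pair could not show this, since compound 1 and compound 2 differ in both the chain count and the group on the ring nitrogen. Compound 3 keeps the silyl group and gives 76.9%, while compound 2 has a free ring nitrogen and gives 80.9%; these values lie within the usual scatter of each other, so with a single chain in place the silyl group makes no readable difference, and the data offer no explanation for the effect of the second chain.

Going by these compounds, it remains open whether a second chain on this ring carbon would lower the reading equally with a free ring nitrogen. On these data alone, it is also open how a shorter chain such as propyl, a longer chain, or an amine at this position would compare, and each reading here comes from one concentration, so none of them gives a potency.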